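A few compounds are considered here, and "the series" means these few. Any claim that something is new, unique, unknown or untested is made for them only; others in the source may bear on it.

In an assay on CHO cells for displacement of a labelled ligand from adenosine receptor A1 (Homo sapiens), read by scintillation counting, tested at 10 uM; on this read-out higher numbers stand for more inhibition at the one concentration tested (going by the name of the read-out) and lower numbers for less inhibition:

- compound 1 `CC(C)(C)Cc1c(-c2ccc(Cl)c(Cl)c2)sc(N)c1C(=O)c1ccc(Cl)cc1`: 1%
- compound 2 `Cc1cccc(-c2sc(N)c(C(=O)c3ccc(Cl)cc3)c2CC(C)(C)C)c1`: 1%
- compound 3 `CC(C)(C)Cc1c(-c2ccccc2)sc(N)c1C(=O)c1ccc(Cl)cc1`: 1%

Compound 3 stands level with compounds 1 and 2 on these numbers; the steps of no change at the digits printed from compound 1 to compound 3 (within the scatter) and no change at the digits printed from compound 2 to compound 3 (within the scatter) lie within the scatter, as does no change at the digits printed from compound 1 to compound 2 (within the scatter). Compound 4 `CC(C)(C)Cc1c(-c2cccs2)sc(N)c1C(=O)c1ccc(Cl)cc1` is the next member to be measured in this assay; it differs from compound 3 by thiophen-2-yl in place of phenyl on an aromatic carbon.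

The three measured steps all exchange the group at this same place and none moved the read-out, so they bear directly on the change, though none of them replaces the phenyl with a five-membered ring. On that basis the expected step is no change at the digits printed from compound 3 to compound 4 (within the scatter), with no change beyond the scatter. Compound 4 is therefore estimated at 1%, expected within -8% to 12%.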

Compound 4, a percentage reported as inhibition, at one concentration (the size of the read-out at that concentration, not a potency): 1%
Beside the measured number, compound 4's estimate shows no gap at the digits printed, within the range that was stated.
By their numbers in this assay, from the lowest: compounds 1, 2, 3 and 4 (each within the scatter of the next).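

Thiophen-2-yl puts a five-membered aromatic ring with a sulfur at this position, next to the ring sulfur, and this assay shows no change at the digits printed from compound 3 to compound 4 (within the scatter). Against the substituted six-membered rings the picture is the same, with no change at the digits printed from compound 2 to compound 4 (within the scatter) for the exchange of 3-methylphenyl and no change at the digits printed from compound 1 to compound 4 (within the scatter) for the exchange of 3,4-dichlorophenyl, so ring size and the ring hetero atom separate none of these four compounds. Nothing at hand offers a reason for this.

Open, on these data alone, is whether a saturated ring such as cyclohexyl, or a carboxylic acid, at this position would move the read-out. Also open, as far as these compounds go, is whether an ethyl chain in place of the neopentyl group would do so.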